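The source may hold more compounds than are shown below. What is called first, only, known or untested is meant among the compounds shown, and "the series" means these compounds.

Compound 1 `Cc1[nH]c(=O)n(C)c1-c1ccc(OC(C)C)cc1` and compound 2 `Cc1[nH]c(=O)n(C2CCCCC2)c1-c1ccc(OC(C)C)cc1` share one core and differ only at the aromatic nitrogen, where compound 2 carries a cyclohexyl instead of a methyl. In a functional assay on brain (Rattus norvegicus, strain Wistar) for inhibition (on this read-out higher numbers stand for weaker inhibition and lower numbers for stronger inhibition), compound 1 gives 20400 nM, and compound 2 gives 13000 nM. For the measured compounds named here, the single measured step, a 1.6-fold lower number from compound 1 to compound 2 (0.20 log units; within the scatter), does not separate the two beyond the scatter. Going by the values given here, of the two numbers measured so far, compound 2 stands at the low end, with compound 1 sitting within the scatter of it, so the pair cannot be told apart on this read-out.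

Compound 3 `Cc1[nH]c(=O)n(C2CCCCC2)c1-c1ccc(-c2ccccc2)cc1` follows from compound 2 by one exchange: phenyl in place of isopropoxy on an aromatic carbon. Among the compounds with values here, no measured step bears on this change; the only step known, from compound 1 to compound 2, concerns the aromatic nitrogen and says nothing about an exchange on an aromatic carbon of the six-membered ring of carbon only. With nothing to guide the direction, the expected step of a 1.2-fold lower number from compound 2 to compound 3 (0.07 log units; within the scatter) is centred on no change beyond the scatter, but with a wide spread. Compound 3 is therefore estimated at 11000 nM, with a range from 2500 nM to 50000 nM in this assay.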

Compound 3, half-maximal inhibitory concentration: 10900 nM
Beside the measured number, compound 3's estimate is 1.0-fold (0.00 log units) above it, within the range that was stated.
By their numbers in this assay, from the lowest: compounds 3, 2 and 1 (each within the scatter of the next).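

For the compounds shown here, the exchange gives the first reading at this position, on an aromatic carbon para to a large group: in this assay, phenyl in place of isopropoxy gives a 1.2-fold lower number from compound 2 to compound 3 (0.08 log units; within the scatter), so compound 2 and compound 3 cannot be told apart on this read-out. The step is not a small swap in what it counts, since the isopropoxy with its oxygen and hydrogen-bond acceptor leaves and a six-membered aromatic ring of carbon only enters, yet with the cyclohexyl and the shared core held in common, this pair shows that the oxygen is not needed to keep the number where compound 2 has it. Nothing measured here explains why the two groups read alike.

Going by these compounds, whether an amine, a carboxylic acid or a longer alkyl chain on this aromatic carbon would move the number beyond the scatter remains open. Also open is whether phenyl at this position would read the same with methyl instead of cyclohexyl on the aromatic nitrogen, as the compounds shown do not include that combination of groups.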